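The source may hold more compounds than are shown below. What is called first, only, known or untested is meant among the compounds shown, and "the series" means these compounds.

Of the compounds shown here, three of a shared core have been tested so far. Compound 1 `COc1cccc(Nc2nccc(-c3cc(C)oc3C)n2)c1` gives 5800 nM in a functional assay for inhibition, with Homo sapiens as the target; on this read-out lower numbers stand for stronger inhibition and higher numbers for weaker inhibition. Compound 2 `CCc1ccc(Nc2nccc(-c3cnccn3)n2)cc1` gives 1900 nM in this assay, and compound 3 `Cc1ccc(Nc2nccc(-c3ccccn3)n2)cc1C` gives 5900 nM in this assay. Among these three numbers, compound 2 has the lowest, and its gap to compound 1 as well as to compound 3 lies beyond the usual scatter, so compound 2 is the strongest inhibitor of the three.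

The next compound to consider is compound 4 `CCc1ccc(Nc2nccc(-c3cc(C)oc3C)n2)cc1`. It differs from compound 2 in a single place: 2,5-dimethylfuran-3-yl in place of pyrazin-2-yl on an aromatic carbon. Compound 1 already carries the 2,5-dimethylfuran-3-yl group, though with a different substituent on the other aryl ring, so it is not a clean comparison; still, compound 1 gives 5800 nM, a weaker value than compound 2.

On this basis, a moderately weaker value is expected for compound 4, with a step from compound 2 of a 2.1-fold higher number from compound 2 to compound 4 (0.32 log units; beyond the scatter), somewhat beyond the scatter. For compound 4 an estimate of 4000 nM in this assay is expected, with a range from 1500 nM to 11000 nM.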

Compound 4, half-maximal inhibitory concentration: 19200 nM
The estimate for compound 4 lay 4.8-fold (0.68 log units) below the measured number, and the stated range ends below it.
By their numbers in this assay, from the lowest: compound 2; then compounds 1 and 3 (each within the scatter of the next); then compound 4.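

In this assay, putting 2,5-dimethylfuran-3-yl in place of pyrazin-2-yl on this aromatic carbon gives a 10-fold higher number from compound 2 to compound 4 (1.00 log units; beyond the scatter) and so means weaker inhibition with the rest of the molecule unchanged. This is the first comparison among these compounds that isolates a single place, and it shows that the group on this carbon, next to the ring nitrogen of the shared core, can by itself move the read-out beyond the usual scatter. Nothing available here explains this loss of inhibition.

Among the compounds shown here, the change also swaps several features at once: a six-membered aromatic ring with 2 hetero atoms leaves, while a five-membered aromatic ring with 1 hetero atom and two methyl groups enters, so the single step cannot assign the loss to any one of them. The compounds shown leave open how a plain phenyl ring or a furan-3-yl group without the methyl groups would compare at this position, and whether the same swap gives a step of similar size when the ethyl group on the other aryl ring is replaced by a carboxylic acid or an amine.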